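This account rests on a few compounds, and the source may have more. Where it says the series, first, only, none or still open, it means among the compounds named here.

Compound 1 `CCOc1cccc(N/C(=N/Nc2ccccc2Cl)C(C)=O)c1` is tested in an assay on isolated protein for binding affinity to corticotropin-releasing factor receptor 1 (Homo sapiens); a higher number here means a weaker inhibitor, a lower number a stronger inhibitor. In this assay compound 1 gives only a limit, > 10000 nM. Compound 2 `CSc1cccc(N/C(=N/Nc2ccccc2Cl)C(C)=O)c1`, with methylsulfanyl in place of ethoxy on an aromatic carbon, also reaches only a limit in this assay, > 10000 nM. The step from compound 1 to compound 2 is thus a step that the two limits leave unreadable from compound 1 to compound 2; the limit of > 10000 nM in this assay, at which 2 of the 2 values shown sit, is all these two values show. Compound 3 `CCOc1cccc(N/C(=N/Nc2ccccc2C(F)(F)F)C(C)=O)c1` differs from compound 1 by trifluoromethyl in place of chloro on an aromatic carbon. Within the data shown here, no measured step bears on this change, and neither limit supplies a number to build from. The expected step from compound 1 to compound 3 is a step that the limit leaves unreadable from compound 1 to compound 3. For compound 3 the estimated value is 15000 nM, within a range from 3000 nM to 60000 nM, most likely again reported only as a limit.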

Compound 3, inhibition constant: > 10000 nM
Compound 3 was reported as a limit; the forecaster's own chance of this, stated with the estimate: 75%; the middle value lies beyond the limit too.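

No step can be read from compound 1 to compound 3, as both stand only as limits in this assay: the limit of > 10000 nM in this assay, at which 3 of the 3 values shown sit. The compounds shown leave open whether any change to the shared core gives a measurable value in this assay.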